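Swapping the side-chain amide on a shared core

This account rests on a few compounds, and the source may have more. Where it says the series, first, only, none or still open, it means among the compounds named here.

Measured compounds:
Compound 1, `Cn1ncc(Cl)c1-c1cc(C(=O)N[C@@H]2CN[C@H](CCn3cncn3)C[C@H]2c2ccc(Cl)c(Cl)c2)oc1Cl`, gives 560 nM.
Compound 2, `CC(=O)NCC[C@@H]1C[C@@H](c2ccc(F)c(F)c2)[C@H](NC(=O)c2cc(-c3c(Cl)cnn3C)c(Cl)o2)CN1`, gives 920 nM.
Compound 3, `C=CC[C@@H]1C[C@@H](c2ccc(Cl)c(Cl)c2)[C@H](NC(=O)c2cc(-c3c(Cl)cnn3C)c(Cl)o2)CN1`, gives 780 nM.

All three were tested in a functional assay on HCT-116 cells (Homo sapiens) for antiproliferative activity, read by sulforhodamine B assay, with a stated time of 72 h; a higher number here means a weaker inhibitor, a lower number a stronger inhibitor. Of the three numbers, that of compound 2 is the highest, but its gaps to compound 3 and to compound 1 both fall within the usual scatter, so the three compounds cannot be told apart on these data.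

The unmeasured compound 4, `CNC(=O)C[C@@H]1C[C@@H](c2ccc(F)c(F)c2)[C@H](NC(=O)c2cc(-c3c(Cl)cnn3C)c(Cl)o2)CN1`, differs from compound 2 in one place: methylcarbamoyl in place of acetamidomethyl on a saturated chain carbon bound to a saturated ring carbon. Going by the values given here, only one measured step is available, a 1.4-fold higher number from compound 1 to compound 3 (0.14 log units; within the scatter). That step also alters the group on the saturated chain carbon bound to a saturated ring carbon, and it stays within the scatter; it does not involve an amide, so it bears on the present change only loosely. Among the compounds with values here, no step shows a large effect of any change at this position, so the step of a 1.0-fold lower number from compound 2 to compound 4 (0.01 log units; within the scatter) is expected to be none beyond the scatter. Compound 4 is therefore estimated to give about 900 nM in this assay, with a range from 400 nM to 2000 nM.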

Compound 4, half-maximal inhibitory concentration: 1100 nM
Estimate against measurement, compound 4: 1.2-fold (0.09 log units) below, and the stated range covers the measured number.
By their numbers in this assay, from the lowest: compounds 1, 3, 2 and 4 (each within the scatter of the next).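

In this assay, going by these compounds alone, the swap from acetamidomethyl to methylcarbamoyl gives a 1.2-fold higher number from compound 2 to compound 4 (0.08 log units; within the scatter), so this is the first measured exchange at this position in which one amide-bearing group replaces another. The side chain goes from 5 heavy atoms to 4 with the same counts of hydrogen-bond donors and acceptors, and on these data the change can't be told apart from no effect, just as with a 1.4-fold higher number from compound 1 to compound 3 (0.14 log units; within the scatter).

As far as these compounds go, whether an amine, a carboxylic acid or a longer chain on this saturated chain carbon would move the number beyond the scatter remains open. So does whether the same amide swap would behave alike on the core of compound 3. No supporting data are available to explain this result.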